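Working notes: removing the pyrrolidinylmethyl group from compound 1

A few compounds are considered here, and "the series" means these few. Any claim that something is new, unique, unknown or untested is made for them only; others in the source may bear on it.

Measured compounds:
compound 1 `COc1cc(OC)c(C(=O)c2cccc(Cl)c2)c(O)c1CN1CCCC1` gives 81%
compound 2 `COc1cc(OC)c(C(=O)c2ccccc2Br)c(O)c1CN1CCCC1` gives 100%
compound 3 `COc1cc(OC)c(C(=O)c2cccc(F)c2)c(O)c1CN1CCCC1` gives 93%

All three values come from a functional assay on THP-1 cells (Homo sapiens) for inhibition, read by ELISA, with stated times of 30 min and 24 h, tested at 10 uM; a lower number here means a weaker effect, a higher number a stronger effect of the compound at the concentration tested. Compound 1 stands lowest of the three numbers: compound 3 is nearest, a number 12 percentage points higher from compound 1 to compound 3 (beyond the scatter), and compound 2 furthest, a number 19 percentage points higher from compound 1 to compound 2 (beyond the scatter). Compound 4 `COc1cc(O)c(C(=O)c2cccc(Cl)c2)c(OC)c1` differs from compound 1 in one place: hydrogen in place of (pyrrolidin-1-yl)methyl on an aromatic carbon. The measured steps all vary the halophenyl on the carbonyl carbon and leave the shared core untouched, so none of them bears on this change, and the data give no guide to its size or direction. On that thin basis the step of a number 26 percentage points lower from compound 1 to compound 4 (beyond the scatter) is expected, with wide uncertainty. Compound 4 is estimated at 55%, within 20% to 85%.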

Compound 4, a percentage reported as activity, at one concentration (the size of the read-out at that concentration, not a potency): 78%
Estimate against measurement, compound 4: 23 percentage points below; measured number inside the range.
By their numbers in this assay, from the lowest: compounds 4 and 1 (each within the scatter of the next); then compounds 3 and 2 (each within the scatter of the next).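

In this assay, hydrogen in place of (pyrrolidin-1-yl)methyl gives a number 3 percentage points lower from compound 1 to compound 4 (within the scatter), the only change shown on the shared core rather than on the halophenyl. With the 3-chlorophenyl group in place, the whole (pyrrolidin-1-yl)methyl group can therefore go without a change beyond the scatter at the single concentration tested. Nothing available explains this result.

From the compounds shown here alone, whether the same holds with 2-bromophenyl or 3-fluorophenyl on the carbonyl carbon remains open. Also open, going by these compounds, is what dimethylaminomethyl or a carboxylic acid would give on this aromatic carbon.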